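The source may hold more compounds than are shown below. What is called first, only, known or untested is meant among the compounds shown, and "the series" means these compounds.

Working notes on the series. Compound 3 `Cc1ccc(C(=O)O)cc1-c1cccc(COc2ccc3c(c2)CN(C2CCCC2)C3=O)c1` shares its core with compound 1 `COc1ccc(C(=O)O)cc1-c1cccc(COc2ccc3c(c2)CN(C2CCCC2)C3=O)c1` and compound 2 `O=C1c2ccc(OCc3cccc(-c4ccc(C(F)(F)F)cc4F)c3)cc2CN1C1CCCC1`. In an assay on HEK293 cells for positive allosteric modulation of metabotropic glutamate receptor 2 (Rattus norvegicus), read by thallium flux (on this read-out lower numbers stand for smaller maximal responses and higher numbers for larger maximal responses), compound 1 gives 79.2%, and compound 3 gives 80.8%; for compound 2 the entry is "not determined" (no result reported). Among the measured compounds shown here, the only measured step, a number 1.6 percentage points higher from compound 1 to compound 3 (within the scatter), leaves the two measured numbers within the scatter of each other, so compound 3 sits level with compound 1 rather than apart from it. Compound 4 `O=C(O)c1ccc(-c2cccc(COc3ccc4c(c3)CN(C3CCCC3)C4=O)c2)c(Cl)c1` differs from compound 3 by 4-carboxy-2-chlorophenyl in place of 5-carboxy-2-methylphenyl on an aromatic carbon. For the measured compounds named here, no measured step covers a change of this kind, so the measured step gives no direction to expect; the estimate rests on the two measured numbers lying close together. For compound 4 the expected value is 78%, range 60% to 95%, an expected step of a number 2.8 percentage points lower from compound 3 to compound 4 (within the scatter).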

Compound 4, largest response reached (reported as percent of maximum), in percent of the reference or control that the assay uses: 89.4%
Compound 4: middle estimate off by 11.4 percentage points, on the low side; the measured number falls inside the stated range.
By their numbers in this assay, from the lowest: compounds 1, 3 and 4 (each within the scatter of the next, the first and the last beyond it).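

In this assay, among the compounds shown here, the 4-carboxy-2-chlorophenyl group gives a number 8.6 percentage points higher from compound 3 to compound 4 (within the scatter) and also a number 10.2 percentage points higher from compound 1 to compound 4 (beyond the scatter) as the first step beyond the scatter. This position on the shared core therefore accepts a chlorine-bearing ring with its carboxy group placed differently, with no loss of maximal response against either earlier compound. Nothing at hand explains the result.

Open, going by these compounds, is whether a nitrile or a bromine in place of the chlorine keeps this maximal response. Also open, on these data alone, is whether a tetrazole can stand in for the carboxylic acid on this ring.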